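The source may report more compounds than this note shows. Statements on the series, on what has been measured and on what is new or still open speak of the compounds shown alone.

Compound 2 `COc1nc(C)c(Nc2nc(Cl)cn([C@H](COC(=O)Nc3ccccc3Cl)C3CC3)c2=O)cc1C` gives 1.5 nM in an assay on frontal cortex for displacement of a labelled ligand from corticotropin-releasing factor receptor 1 (Rattus norvegicus), with a stated time of 2 h (a lower number here means a stronger inhibitor, a higher number a weaker inhibitor), the lowest of the three numbers measured. Compound 3 `COc1nc(C)c(Nc2nc(Cl)cn([C@H](COC(=O)Nc3cc(Cl)cc(Cl)c3)C3CC3)c2=O)cc1C` gives 1.7 nM, and the two lie within the scatter of each other, as a 1.1-fold higher number from compound 2 to compound 3 (0.05 log units; within the scatter) shows. Compound 1 `COc1nc(C)c(Nc2nc(Cl)cn([C@H](COC(C)=O)C3CC3)c2=O)cc1C` gives 5.3 nM. Compound 4 `CCNC(=O)OC[C@H](C1CC1)n1cc(Cl)nc(Nc2cc(C)c(OC)nc2C)c1=O` differs from compound 2 by ethyl in place of 2-chlorophenyl on an amide-type nitrogen. Within the data shown here, two measured steps bear on this change: a 3.5-fold lower number from compound 1 to compound 2 (0.55 log units; beyond the scatter) and a 3.1-fold lower number from compound 1 to compound 3 (0.49 log units; beyond the scatter), both modest gains when a phenylamino group replaced methyl on a carbonyl carbon. Among the measured compounds shown here, no measured step covers an ethylamino group, which is neither methyl nor one of those phenylamino groups. A modest rise in number is therefore expected, with the step of a 2.3-fold higher number from compound 2 to compound 4 (0.37 log units; beyond the scatter). Compound 4 is estimated at 3.5 nM, with a range from 1.5 nM to 8 nM.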

Compound 4, half-maximal inhibitory concentration: 14 nM
The estimate for compound 4 lay 4.0-fold (0.60 log units) below the measured number, and the stated range ends below it.
By their numbers in this assay, from the lowest: compounds 2 and 3 (each within the scatter of the next); then compound 1; then compound 4.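

Replacing the aromatic ring on the amide-type nitrogen with ethyl weakens binding, with a 9.3-fold higher number from compound 2 to compound 4 (0.97 log units; beyond the scatter) and an 8.2-fold higher number from compound 3 to compound 4 (0.92 log units; beyond the scatter), so ethyl does not stand in for 2-chlorophenyl or 3,5-dichlorophenyl here. Ethylamino also falls short of plain methyl on the carbonyl carbon, with a 2.6-fold higher number from compound 1 to compound 4 (0.42 log units; beyond the scatter), so extending from that carbonyl does not by itself give a stronger inhibitor. Nothing available explains this loss. On these data alone, whether unsubstituted phenyl or benzyl would match compound 2 remains open. So does whether a longer chain, such as butyl, would behave like ethyl.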